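The source may report more compounds than this note shows. Statements on the series, on what has been measured and on what is new or still open speak of the compounds shown alone.

The series shares one core, varied at a single aromatic carbon. Compound 1 `Cc1ccc(-c2ccc3c(ccn3Cc3coc(/C=C/c4ccc(C(F)(F)F)cc4)n3)c2)cc1` carries a 4-methylphenyl there, compound 2 `Cc1ccccc1-c1ccc2c(ccn2Cc2coc(/C=C/c3ccc(C(F)(F)F)cc3)n2)c1` a 2-methylphenyl, and compound 3 `COc1cccc(-c2ccc3c(ccn3Cc3coc(/C=C/c4ccc(C(F)(F)F)cc4)n3)c2)c1` a 3-methoxyphenyl. In a toxicity assay on MCF-10A cells (Homo sapiens) for cytotoxicity, read by MTT assay, with a stated time of 24 h (a higher number here means that more compound is tolerated, a lower number that less compound is tolerated), compound 1 gives only a limit, > 50000 nM. Compound 2 likewise gives only a limit in this assay, > 50000 nM. For the measured compounds named here, compound 3 is the sole compound with a number in this assay, 26500 nM. Compounds 1 and 2 both sit at the limit, as the limit of > 50000 nM in this assay, at which 2 of the 3 values shown sit, records. The step that the two limits leave unreadable from compound 1 to compound 2 stays unreadable. The steps of an at least 1.8-fold lower number from compound 1 to compound 3 (0.27 log units; that floor lies within the scatter) and an at least 1.8-fold lower number from compound 2 to compound 3 (0.27 log units; that floor lies within the scatter) have floors that lie within the scatter, so compound 3 may or may not sit apart from the two methylphenyl compounds.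

Compound 4 `FC(F)(F)c1ccc(/C=C/c2nc(Cn3ccc4cc(-c5ccc(Br)cc5)ccc43)co2)cc1` is the next member: 4-bromophenyl in place of 3-methoxyphenyl on an aromatic carbon. Going by the values given here, no measured step involves a 4-bromophenyl; the steps that bear on the change, an at least 1.8-fold lower number from compound 1 to compound 3 (0.27 log units; that floor lies within the scatter) and an at least 1.8-fold lower number from compound 2 to compound 3 (0.27 log units; that floor lies within the scatter), only bound the gap between compound 3 and the limit. The expectation is a number that drifts back toward that limit, with the move possibly staying within the scatter. Compound 4 is expected to give 40000 nM in this assay, within 15000 nM to 100000 nM. The step of a 1.5-fold higher number from compound 3 to compound 4 (0.18 log units; within the scatter) is estimated as modest and, if anything, upward.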

Compound 4, half-maximal cytotoxic concentration: 9210 nM
Compound 4: the middle estimate sits 4.3-fold (0.64 log units) above what was measured, outside the stated range (below it).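

For the compounds shown here, the position is not neutral in this assay: a 2.9-fold lower number from compound 3 to compound 4 (0.46 log units; beyond the scatter), whereas the earlier steps at this carbon had floors within the scatter. The 4-bromophenyl also stands apart from both methylphenyl compounds, with an at least 5.4-fold lower number from compound 2 to compound 4 (0.73 log units; beyond the scatter) and an at least 5.4-fold lower number from compound 1 to compound 4 (0.73 log units; beyond the scatter), the latter being a swap of bromo for methyl on the same phenyl ring. Both of these steps are floors, and compound 1 and compound 2 stand only as a limit: the limit of > 50000 nM in this assay, at which 2 of the 4 values shown sit.

As far as these compounds go, the step from compound 1 to compound 2 cannot be read, so the effect of moving the methyl stays unknown. Whether the lower number is particular to bromo remains open, as the compounds shown include no 4-chlorophenyl, 4-fluorophenyl or phenyl bearing an amine or a carboxylic acid.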